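This account rests on a few compounds, and the source may have more. Where it says the series, first, only, none or still open, it means among the compounds named here.

Three compounds that share one core and differ only in the heteroaryl group on a saturated chain carbon bound to an amide-type nitrogen in a ring have been measured. In a functional assay on HCT-116 cells (Homo sapiens) for inhibition, read by MTT assay, with a stated time of 48 h, tested at 2 uM (on this read-out higher numbers stand for more inhibition at the one concentration tested (going by the name of the read-out) and lower numbers for less inhibition), compound 1 `Cc1noc(C)c1-c1ccc2c(c1)C(c1ccccc1)N(Cc1nnc(-c3ccccc3)o1)C(=O)N2C` gives 31.4%, compound 2 `Cc1noc(C)c1-c1ccc2c(c1)C(c1ccccc1)N(Cc1ncc(-c3ccccc3)o1)C(=O)N2C` gives 30%, and compound 3 `Cc1noc(C)c1-c1ccc2c(c1)C(c1ccccc1)N(Cc1nc(-c3ccc(F)cc3)cs1)C(=O)N2C` gives 33.3%. Compound 3 shows the highest of the three numbers, yet the steps of a number 1.9 percentage points higher from compound 1 to compound 3 (within the scatter) and a number 3.3 percentage points higher from compound 2 to compound 3 (within the scatter) both fall within the scatter, as does a number 1.4 percentage points lower from compound 1 to compound 2 (within the scatter). Compound 4 `Cc1noc(C)c1-c1ccc2c(c1)C(c1ccccc1)N(Cc1csc(-c3ccc(F)cc3)n1)C(=O)N2C` keeps the same atoms in a different arrangement: 2-(4-fluorophenyl)-1,3-thiazol-4-yl in place of 4-(4-fluorophenyl)-1,3-thiazol-2-yl on a saturated chain carbon bound to an amide-type nitrogen in a ring. Every measured swap of this group left this assay unchanged beyond the scatter, so no step beyond the scatter is expected here either, meaning a number 1.3 percentage points lower from compound 3 to compound 4 (within the scatter). Compound 4 is therefore estimated at 32%, between 22% and 42%.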

Compound 4, a percentage reported as inhibition, at one concentration (the size of the read-out at that concentration, not a potency): 31.8%
For compound 4 the middle estimate is 0.2 percentage points above the measured one, within the range that was stated.
By their numbers in this assay, from the lowest: compounds 2, 1, 4 and 3 (each within the scatter of the next).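

In this assay, joining the same atoms differently at the saturated chain carbon gives a number 1.5 percentage points lower from compound 3 to compound 4 (within the scatter), so swapping these two thiazole arrangements produces no change this read-out can resolve. Compound 4 also sits close to the other heteroaryl compounds, with a number 1.8 percentage points higher from compound 2 to compound 4 (within the scatter) and a number 0.4 percentage points higher from compound 1 to compound 4 (within the scatter). No measurement at hand explains this lack of change.

On these data alone, all four groups pair a five-membered aromatic ring with phenyl or 4-fluorophenyl, so it remains open whether an amine, a carboxylic acid or a longer alkyl chain in this place would move the number beyond the scatter.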